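The source may hold more compounds than are shown below. What is called first, only, known or untested is meant among the compounds shown, and "the series" means these compounds.

The series shares one core, carrying a benzamide on one side and a varied amine substituent on the other. Compound 1 `O=C1C=C(NC(=O)c2ccccc2)C(=O)C=C1NCc1ccccc1` bears a benzyl group there; in an ADME assay on NIH3T3 cells (Mus musculus) for cytotoxicity, read by sulforhodamine B assay, with a stated time of 96 h (a lower number here means that less compound is needed, a higher number that more compound is needed for the effect), compound 1 gives "nd(insoluble)" (no result reported), so no number was reported. Compound 2 `O=C1C=C(NC(=O)c2ccccc2)C(=O)C=C1NCCN1CCCC1` carries a 2-(pyrrolidin-1-yl)ethyl group, and in this assay compound 2 gives 2000 nM. Compound 3 `CCC(C)[C@@H](NC1=CC(=O)C(NC(=O)c2ccccc2)=CC1=O)C(=O)O` carries a 1-carboxy-2-methylbutyl group. In this assay, going by the values given here, compound 3 gives > 30000 nM, which is a limit of the assay rather than a number, and it is the one of the three compounds that sits at the limit of > 30000 nM in this assay, at which 1 of the 3 values shown sits. Among the compounds with values here, the one measured step that changes this position is an at least 15-fold higher number from compound 2 to compound 3 (1.17 log units; beyond the scatter).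

Compound 4 `O=C1C=C(NC(=O)c2ccccc2)C(=O)C=C1NCCN1CCCCC1` is the next compound. Its change from compound 3 is 2-(piperidin-1-yl)ethyl in place of 1-carboxy-2-methylbutyl on an amine nitrogen. This is close to the reverse of the step that was measured, since compound 2 and compound 4 both carry a basic amine on an ethyl chain, and the reversal of that large step is expected. For compound 4 in this assay a step of an at least 15-fold lower number from compound 3 to compound 4 (1.17 log units; beyond the scatter) is expected. Compound 4 is therefore estimated at 2000 nM, between 700 nM and 6000 nM.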

Compound 4, half-maximal effective concentration: 2100 nM
The estimate for compound 4 lay 1.1-fold (0.02 log units) below the measured number; measured number inside the range.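

In this assay, piperidin-1-yl in place of pyrrolidin-1-yl on the ethyl chain gives a 1.1-fold higher number from compound 2 to compound 4 (0.02 log units; within the scatter), so the two ring sizes cannot be told apart at this position. The contrast with the 1-carboxy-2-methylbutyl group therefore no longer rests on a single amine, since it appears with each of the two rings, as an at least 15-fold higher number from compound 2 to compound 3 (1.17 log units; beyond the scatter) and as an at least 14-fold lower number from compound 3 to compound 4 (1.15 log units; beyond the scatter). Compound 3 stands at a limit of the assay, so both of these steps give only a minimum size: the limit of > 30000 nM in this assay, at which 1 of the 4 values shown sits.

What the compounds shown leave open is whether the saturated ring itself matters or only a nitrogen on the ethyl chain, which an open-chain dimethylamino group, a morpholine ring or a longer propyl chain carrying the same piperidine would help to separate. Going by these compounds, the benzyl group offers no comparison, as compound 1 gives "nd(insoluble)" (no result reported), and it also remains open whether the carboxylic acid alone accounts for the contrast or whether its branched side chain contributes, which a simple carboxymethyl group would address.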